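The compounds below may be only part of what the source reports. "The series", "measured", "known", "first", "only" and "open" are said of these compounds alone.

Compound 1 `CCCCCCCCCCNC(=O)C1C(C(=O)O)[C@@H]2CC[C@H]1O2`: 10000 nM
Compound 2 `O=C(O)C1C(C(=O)NCC2Cc3ccsc3CO2)[C@H]2CC[C@@H]1O2`: 10000 nM

Both compounds were tested in an ADME assay on A-431 cells (Homo sapiens) for cytotoxicity, read by MTT assay, with a stated time of 72 h; a lower number here means a stronger inhibitor of growth, a higher number a weaker inhibitor of growth. In this test, compound 1 gives 10000 nM, level with compound 2 at 10000 nM. Neither compound can therefore be ranked above the other.

Compound 3 `CCCCNC(=O)C1C(C(=O)O)[C@@H]2CC[C@H]1O2` has not yet been measured. It keeps the shared core of compound 1, and the change lies in the chain on the amide: hydrogen in place of hexyl on a saturated chain carbon, four bonds along the chain from an amide-type nitrogen. In words, this is hydrogen in place of hexyl on a saturated chain carbon, four bonds along the chain from an amide-type nitrogen.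

Going by the values given here, no pair of measured compounds shows this change on its own, so the data give no direct size for it. Among the compounds with values here, the only guide is that compound 1 gives 10000 nM and compound 2 gives 10000 nM, which offers no sign of movement in either direction. The expected no change at the digits printed from compound 1 to compound 3 (within the scatter) is therefore no step beyond the scatter, and this expectation is a weak one. For compound 3 the estimated value is 10000 nM, with an expected range of 5000 nM to 20000 nM.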

Compound 3, concentration for 50% growth inhibition: 10000 nM
The estimate for compound 3 equals the measured number at the digits printed; low and high end bracket the measured number.
By their numbers in this assay, from the lowest: compounds 1, 2 and 3 (each within the scatter of the next).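

In this assay, taking the hexyl stretch off the chain on the amide gives no change at the digits printed from compound 1 to compound 3 (within the scatter). Going by these compounds alone, this is the first direct reading of a single change at this position, where earlier there was only the level pair of compound 1 and compound 2, which differ in more than one place. For this one pair, the hexyl stretch on a saturated chain carbon, four bonds along the chain from an amide-type nitrogen, can be replaced by hydrogen without a shift in the number beyond the usual scatter, and no measurement at hand explains that flat result.

Within the data shown here, all three compounds stand level, so this step shows only that the two chains give the same reading, not that the chain on the amide could never matter, since no compound here gives a reading away from that shared value. Still open, on these data alone, is whether a different group at this position, such as a terminal amine or a phenyl ring on the chain, would move the number in either direction.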